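Swapping piperidine for morpholine on the thiocarbonyl carbon

This account rests on a few compounds, and the source may have more. Where it says the series, first, only, none or still open, it means among the compounds named here.

Compound 1 `CCOC(=O)c1cc(=O)c2cc(CSC(=S)N3CCCC3)ccc2o1` reaches only a limit of the assay, > 25000 nM in a functional assay on MCF7 cells (Homo sapiens) for antiproliferative activity, read by MTT assay, with a stated time of 72 h; on this read-out higher numbers stand for weaker inhibition and lower numbers for stronger inhibition. Compound 2 `CCOC(=O)c1cc(=O)c2cc(CSC(=S)N3CCCCC3)ccc2o1` gives the only plain number shown, 21900 nM, a weak inhibition. The step of an at least 1.1-fold lower number from compound 1 to compound 2 (0.05 log units; that floor lies within the scatter) stays within the scatter. Compound 3 `CCOC(=O)c1cc(=O)c2cc(CSC(=S)N3CCOCC3)ccc2o1` differs from compound 2 by morpholin-4-yl in place of piperidin-1-yl on a thiocarbonyl carbon. Among the measured compounds shown here, that single measured step, a change of the ring on the same carbon, is the only guidance, and it moved the number little. No step beyond the scatter is therefore expected, and compound 3 is estimated at 28000 nM (range 12000 nM to 80000 nM). The expected step is a 1.3-fold higher number from compound 2 to compound 3 (0.11 log units; within the scatter).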

Compound 3, half-maximal inhibitory concentration: > 25000 nM
Compound 3: a limit, no number; the forecaster's own chance of this, stated with the estimate: 55%; the middle value is on the limit's open side.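

In this assay, compound 3 gives only a limit, so the change from the ring of compound 2 to morpholin-4-yl can be read only as a floor, an at least 1.1-fold higher number from compound 2 to compound 3 (0.05 log units; that floor lies within the scatter). Putting an oxygen into the ring on this thiocarbonyl carbon therefore gives no sign of stronger inhibition, and the step from compound 1 to compound 3 cannot be read, both values being limits. The three rings shown all stay at the weak end of the read-out: the limit of > 25000 nM in this assay, at which 2 of the 3 values shown sit.

Still open, from the compounds shown here alone, is whether an open-chain diethylamino group or a piperazine ring with a free amine on the same carbon would give a clearly lower number. Going by these compounds, the actual values of compound 1 and compound 3 also remain unknown.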